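Cytotoxicity in the series: from compound 3 to compound 4

The source may hold more compounds than are shown below. What is called first, only, known or untested is meant among the compounds shown, and "the series" means these compounds.

Compound 1 `CCN(CC)c1ccc2cc(C(=O)c3ccc(N4CCN(C(=O)CN5CCN(C(=O)/C=C/c6ccccc6)CC5)CC4)cc3)oc2c1` and compound 2 `CCN(CC)c1ccc2cc(C(=O)c3ccc(N4CCN(C(=O)CN5CCN(S(=O)(=O)C6CC6)CC5)CC4)cc3)oc2c1` differ only at the amine nitrogen in the ring, and both are read in an ADME assay on L02 cells (Homo sapiens) for cytotoxicity, read by MTT assay, with a stated time of 48 h (a lower number here means a stronger inhibitor, a higher number a weaker inhibitor), as a limit of the assay. Compound 1 gives > 100000 nM, a limit. Compound 2 gives > 100000 nM, also a limit. Their comparison, a step that the two limits leave unreadable from compound 1 to compound 2, cannot be sized because the limit of > 100000 nM in this assay, at which 2 of the 3 values shown sit, covers both. For the measured compounds named here, compound 3 `CCN(CC)c1ccc2cc(C(=O)c3ccc(N4CCN(C(=O)CN5CCN(Cc6ccc(F)c(F)c6)CC5)CC4)cc3)oc2c1` is the only member with a number: in this assay compound 3 gives 10200 nM, and the steps of an at least 9.8-fold lower number from compound 1 to compound 3 (0.99 log units; beyond the scatter) and an at least 9.8-fold lower number from compound 2 to compound 3 (0.99 log units; beyond the scatter) both point the same way, with the 3,4-difluorobenzyl group entering.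

Compound 4 `CCOC(=O)CN1CCN(CC(=O)N2CCN(c3ccc(C(=O)c4cc5ccc(N(CC)CC)cc5o4)cc3)CC2)CC1` is not yet measured. Against compound 3 the change is ethoxycarbonyl in place of 3,4-difluorophenyl on a saturated chain carbon bound to an amine nitrogen in a ring. This removes the very group whose arrival in compound 3 coincided with the lower number, and puts in its place a small oxygen-bearing group closer in kind to the appendages of compound 1 and compound 2. Both bearing steps are at least modest, so compound 4 is expected to move back toward the limit, an expected step of a 7.8-fold higher number from compound 3 to compound 4 (0.89 log units; beyond the scatter). The estimate for compound 4 in this assay is 80000 nM, with a range from 20000 nM to 300000 nM, and a fair chance that only a limit is reported.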

Compound 4, half-maximal inhibitory concentration: 68700 nM
For compound 4 the middle estimate is 1.2-fold (0.07 log units) above the measured one, within the range that was stated.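

For the compounds shown here, at this place, on a saturated chain carbon bound to an amine nitrogen in a ring, ethoxycarbonyl in place of 3,4-difluorophenyl gives in this assay a 6.7-fold higher number from compound 3 to compound 4 (0.83 log units; beyond the scatter) as the first step with a number at both ends. The lower number of compound 3 is therefore not carried by the shared core and the linking chain alone, since it does not survive this single change. The steps of an at least 1.4-fold lower number from compound 2 to compound 4 (0.16 log units; that floor lies within the scatter) and an at least 1.4-fold lower number from compound 1 to compound 4 (0.16 log units; that floor lies within the scatter) are floors only, and compound 4 cannot be placed any further against those two compounds because their values are limits: the limit of > 100000 nM in this assay, at which 2 of the 4 values shown sit.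

From the compounds shown here alone, it remains open whether the number of compound 3 goes with the aromatic ring itself or with its two fluorines, a question that a plain benzyl group or a 4-fluorobenzyl group at the same amine nitrogen would address. Also open, going by these compounds, is how a simple butyl chain or a free carboxylic acid in place of ethoxycarbonyl would read in this assay.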